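The compounds below may be only part of what the source reports. "The series", "measured", "known", "first", "only" and "open" are said of these compounds alone.

Compound 1 `Cc1nc2c(CCc3ccccc3)cccn2c1N` stands at the top of the three doses recorded so far: in a functional assay on the whole organism (stomach) with Canis familiaris (Canis lupus familiaris) as the target (a higher number here means that more compound is needed for the effect, a lower number that less compound is needed), compound 1 needs 1 mg/kg. Compound 2 `Cc1nc2c(OCc3ccccc3)cccn2c1N` gives 0.1 mg/kg in this assay, and compound 3 `Cc1nc2c(OCc3ccccc3)cccn2c1CO` gives 0.3 mg/kg. Against both of them compound 1 lies beyond the scatter, so of the three it asks for the most material.

Compound 4 `Cc1nc2c(CCc3ccccc3)cccn2c1C` is the next member of the series; it differs from compound 1 by methyl in place of amino on an aromatic carbon. For the measured compounds named here, only one measured step touches the same aromatic carbon of the shared core: a 3.0-fold higher number from compound 2 to compound 3 (0.48 log units; beyond the scatter), hydroxymethyl in place of amino, a modest shift. Methyl in place of amino is a different swap, yet it likewise removes the amino group with its one hydrogen-bond donor and one hydrogen-bond acceptor, so a modest rise in the dose in this assay is the more likely outcome, though a step that stays within the scatter cannot be ruled out.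

On that basis compound 4 is expected to come out near 3 mg/kg, with a plausible range from 1 mg/kg to 10 mg/kg. Such an estimate would mean an expected step of a 3.0-fold higher number from compound 1 to compound 4 (0.48 log units; beyond the scatter), to be checked against the measurement.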

Compound 4, dose for half-maximal effect in the Canis familiaris assay: 0.2 mg/kg
For compound 4 the middle estimate is 15-fold (1.18 log units) above the measured one; measured number below the stated range.
By their numbers in the Canis familiaris assay, from the lowest: compounds 2, 4 and 3 (each within the scatter of the next, the first and the last beyond it); then compound 1.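

In the Canis familiaris assay, methyl in place of amino on this aromatic carbon gives a 5.0-fold lower number from compound 1 to compound 4 (0.70 log units; beyond the scatter), with compound 4 at 0.2 mg/kg and compound 1 at 1 mg/kg, and so shows that, with the side chain of compound 1, the amino group and its hydrogen-bond donor are not needed for a low dose at this position. The earlier step at the same carbon, where in the Canis familiaris assay hydroxymethyl in place of amino gives a 3.0-fold higher number from compound 2 to compound 3 (0.48 log units; beyond the scatter) on a core with a different side chain, runs the opposite way, so the two replacements of amino at this position do not share one direction across the compounds shown. In a physicochemical assay for acid dissociation, compound 1 gives 7.3 and compound 4 gives 7.5. In the physicochemical assay the change gives a number 0.20 log units higher from compound 1 to compound 4 (within the scatter) and no supporting information accounts for the step in dose.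

The compounds shown leave open whether the direction of these steps follows from the group that enters or from the side chain, since methyl appears at this carbon only with the side chain of compound 1 and hydroxymethyl only with that of compound 2. They also leave open how an ethyl group, a chlorine atom or a dimethylamino group at this carbon would compare with methyl in the dose required.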